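A few compounds are considered here, and "the series" means these few. Any claim that something is new, unique, unknown or untested is made for them only; others in the source may bear on it.

The measured compounds, with their values in an assay on HeLa cells for displacement of a labelled ligand from 5-hydroxytryptamine receptor 6 (Homo sapiens), with a stated time of 2 h; on this read-out higher numbers stand for weaker inhibition and lower numbers for stronger inhibition:

compound 1, `O=S(=O)(c1cccc(F)c1)c1cn(C2CCNC2)c2ccccc12`, gives 4.7 nM.
compound 2, `CN1CCC(n2cc(S(=O)(=O)c3cccc(F)c3)c3ccccc32)C1`, gives 3.5 nM.
compound 3, `CN1CCC(n2cc(S(=O)(=O)c3cccc(F)c3)c3cc(F)ccc32)C1`, gives 5 nM.

Compound 4, `O=S(=O)(c1cccc(F)c1)c1cn(C2CCNC2)c2cc(F)ccc12`, has not yet been measured in this assay. It is obtained from compound 1 by the change (fluoro in place of hydrogen on an aromatic carbon). This change has already been made once among the measured compounds: compound 3 arises from compound 2 by fluoro in place of hydrogen on an aromatic carbon, and that step gave a 1.4-fold higher number from compound 2 to compound 3 (0.15 log units; within the scatter). The place of the change is described in the same words for both pairs, so it is the same change, not merely the same kind. The two cores on which it is made differ by hydrogen in place of methyl on an amine nitrogen in a ring; the step in the other direction gave a 1.3-fold lower number from compound 1 to compound 2 (0.13 log units; within the scatter).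

For the measured compounds named here, for compound 4 the expected step is a 1.4-fold higher number from compound 1 to compound 4 (0.14 log units; within the scatter), because the same change gave a 1.4-fold higher number from compound 2 to compound 3 (0.15 log units; within the scatter) and a comparable outcome is the only guide available. Compound 4 is therefore estimated at 6.5 nM, with a likely range from 3 nM to 14 nM.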

Compound 4, inhibition constant: 18 nM
For compound 4 the middle estimate is 2.8-fold (0.44 log units) below the measured one, outside the stated range (above it).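

In this assay, fluoro in place of hydrogen on the core of compound 1, which has hydrogen on the ring amine nitrogen, gave a 3.8-fold higher number from compound 1 to compound 4 (0.58 log units; beyond the scatter), and this outcome does not match the one seen on the core with methyl on that nitrogen: the same change on two cores in this assay, a 1.4-fold higher number (0.15 log units; within the scatter) from compound 2 to compound 3 and a 3.8-fold higher number (0.58 log units; beyond the scatter) from compound 1 to compound 4, 2.7-fold (0.43 log units) apart, beyond the scatter of two such steps

The size of the step therefore did not carry over from one core to the other, so a value for this change on one of these cores is a poor guide to its value on the other. For the compounds shown here, this rests on only two matched pairs, however, and it does not show why the steps differ or how the change would behave on any further core.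

The compounds shown leave open whether an ethyl or acetyl group on the ring amine nitrogen would give a step closer to that on the hydrogen core or the methyl core. They also leave open whether chloro or methoxy at the same place would follow the fluoro steps on these two cores.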